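The compounds below may be only part of what the source reports. "The series", "measured", "known", "first", "only" and "open" are said of these compounds alone.

Measured compounds in a functional assay on CHO-K1 cells for agonist activity at Glucose-dependent insulinotropic receptor (Homo sapiens), read by a luciferase reporter, with a stated time of 5 h; on this read-out higher numbers stand for an effect only at larger amounts of compound and lower numbers for an effect already at smaller amounts:

- compound 1, `CC(C)OC(=O)N1CCC(COc2ccc(N3CCN(C(=O)N(C)C)CC3)nc2)CC1`: a limit only, > 10000 nM
- compound 2, `CCS(=O)(=O)N1CCN(c2ccc(OCC3CCN(C(=O)OC(C)C)CC3)cn2)CC1`: 1300 nM
- compound 3, `CC(C)OC(=O)N1CCC(COc2ccc(N3CCN(S(=O)(=O)C(C)C)CC3)nc2)CC1`: 300 nM

Compound 3 holds the lowest of the two numbers in this assay; the nearest is compound 2, separated by a 4.3-fold lower number from compound 2 to compound 3 (0.64 log units; beyond the scatter), a step that changes only the alkyl on the sulfonyl sulfur. Compound 1 is reported only at the limit of > 10000 nM in this assay, at which 1 of the 3 values shown sits, so the step of an at least 33-fold lower number from compound 1 to compound 3 (1.52 log units; beyond the scatter) is a bound on the gain when the sulfonyl replaces the dimethylcarbamoyl.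

Compound 4, `CCCCS(=O)(=O)N1CCN(c2ccc(OCC3CCN(C(=O)OC(C)C)CC3)cn2)CC1`, differs from compound 3 by butyl in place of isopropyl on a sulfonyl sulfur. For the measured compounds named here, the only measured step that bears on it is a 4.3-fold lower number from compound 2 to compound 3 (0.64 log units; beyond the scatter), in which a larger alkyl on the sulfonyl sulfur lowered the number modestly. Butyl is larger again but unbranched, and no measured pair separates branching from size. The expectation for compound 4 in this assay is therefore a number close to compound 3, with the step of no change at the digits printed from compound 3 to compound 4 (within the scatter) estimated to fall within the scatter. The estimated value for compound 4 is 300 nM, in a range from 100 nM to 1000 nM.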

Compound 4, half-maximal effective concentration: 100 nM
The estimate for compound 4 lay 3.0-fold (0.48 log units) above the measured number; measured number inside the range.
By their numbers in this assay, from the lowest: compound 4; then compound 3; then compound 2. At a limit, above all of these: compound 1.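

In this assay the alkyl on the sulfonyl sulfur has not reached its limit at isopropyl: a 3.0-fold lower number from compound 3 to compound 4 (0.48 log units; beyond the scatter), so the unbranched butyl continues the fall in the number. Ethyl, isopropyl and butyl now fall in that order, with none of the three going against it, and the full span reads a 13-fold lower number from compound 2 to compound 4 (1.11 log units; beyond the scatter). The step from the dimethylcarbamoyl, an at least 100-fold lower number from compound 1 to compound 4 (2.00 log units; beyond the scatter), is only a bound, as compound 1 is a limit: the limit of > 10000 nM in this assay, at which 1 of the 4 values shown sits.

Going by these compounds, whether a longer chain such as pentyl would lower the number further, or a phenyl on the same sulfur would hold it, stays open. Chain length and the absence of branching also remain unseparated, and a propyl and a tert-butyl at this place would be needed to tell them apart.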